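A few compounds are considered here, and "the series" means these few. Any claim that something is new, unique, unknown or untested is made for them only; others in the source may bear on it.

Of the compounds shown here, two have been measured in a physicochemical assay for lipophilicity (on this read-out lower numbers stand for lower lipophilicity and higher numbers for higher lipophilicity), so far. Compound 1, `O=S1(=O)Nc2ccccc2N1`, has a cyclic sulfamide fused to a benzene ring, and in this assay compound 1 gives 1.12. Compound 2, `O=S(=O)(CF)Nc1ccccc1`, is an open-chain sulfonamide on an aniline nitrogen carrying a fluoromethyl group on the sulfonyl sulfur, and in this assay compound 2 gives 1.35. Within the data shown here, its only neighbour on this read-out is compound 1, and the gap between the two values lies within the scatter of repeated measurements, so the two cannot be told apart on these numbers.

The account now moves from compound 2 to compound 3, `CS(=O)(=O)Nc1ccccc1`, which has not yet been measured in this assay. The change is small: hydrogen in place of fluoro on a saturated chain carbon bound to a sulfonyl sulfur. Among the measured compounds shown here, no measured pair in this set shows a step of this kind, so there is no direct guide to its size. A small downward step in this assay is expected, of the order of a number 0.35 log units lower from compound 2 to compound 3 (beyond the scatter), close to the edge of the scatter. For compound 3 in this assay the estimate is 1, with a range from 0.6 to 1.4.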

Compound 3, partition coefficient: 0.95
Compound 3: the middle estimate sits 0.05 log units above what was measured; the measured number falls inside the stated range.
By their numbers in this assay, from the lowest: compounds 3, 1 and 2 (each within the scatter of the next, the first and the last beyond it).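

In this assay, among these compounds, the change from fluoromethyl to methyl gives the first step in this set that can be read at a single place, and it comes to a number 0.40 log units lower from compound 2 to compound 3 (beyond the scatter) on a saturated chain carbon bound to a sulfonyl sulfur. The two earlier compounds gave no such reading, as compound 1 and compound 2 differ in more than one place and their values could not be told apart; this pair shows that hydrogen in place of one fluoro, with the rest of the structure unchanged, is enough to carry the number past the scatter. No measurement available here explains the direction or the size of this step.

On these data alone, this remains one step from one pair, so it is open whether the same change would give a similar step on the core of compound 1 or at any other place. As far as these compounds go, it is also open whether a difluoromethyl or trifluoromethyl group, or a longer chain such as ethyl, on the sulfonyl sulfur would extend this step, leave the number within the scatter, or move it the other way.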